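Lengthening the Short Chain

The source may report more compounds than this note shows. Statements on the series, on what has been measured and on what is new or still open speak of the compounds shown alone.

In a toxicity assay on cells (Erythrocyte, Homo sapiens) for cytotoxicity, read by hemolysis (a higher number here means that more compound is needed for the effect, a lower number that less compound is needed), compound 2 (`CCCCCC(=O)NCc1ccc(C(=O)N[C@H](C(=O)O)[C@@H](C)CC)cc1`) gives > 1500 ug/mL as a limit of the assay and not a number. Compound 3 (`CCCCCCCCCC(=O)NCc1ccc(C(=O)N[C@H](C(=O)O)[C@@H](C)CC)cc1`) differs from it by butyl in place of hydrogen on a saturated chain carbon, five bonds along the chain from a carbonyl carbon with butyl in place of hydrogen on a saturated chain carbon, five bonds along the chain from a carbonyl carbon. Compound 1 (`CCCCCCCCCCCCCC(=O)NCc1ccc(C(=O)N[C@H](C(=O)O)[C@@H](C)CC)cc1`) gives 66 ug/mL and has octyl at that place. Going by the values given here, the one measured step that bears on this is an at least 22-fold higher number from compound 1 to compound 2 (1.35 log units; beyond the scatter) with hydrogen in place of octyl. Butyl is the shorter group, so a smaller move toward a lower number is expected in this assay here. The estimated move is an at least 3.3-fold lower number from compound 2 to compound 3 (0.52 log units; beyond the scatter) for this change. For compound 3 the expected value is 450 ug/mL within an estimated range of 130 ug/mL to 1500 ug/mL in all.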

Compound 3, half-maximal effective concentration: > 1000 ug/mL
Compound 3: no number, only a limit; the forecaster's own chance of this, stated with the estimate: 25%; at least 2.2-fold (0.34 log units) between middle value and limit.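

In this assay compound 3 gives > 1000 ug/mL, which is a limit of the assay and not a number. Butyl at this place therefore leaves the chain well short of what octyl does, with an at least 15-fold higher number from compound 1 to compound 3 (1.18 log units; beyond the scatter), so the large drop in the number needs more than butyl here. Compound 2 and compound 3 both carry limits, and the step joining them cannot be read.

Still open, as far as these compounds go, is what hexyl at this place gives, and whether a chain longer than octyl lowers the number further.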